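This account rests on a few compounds, and the source may have more. Where it says the series, first, only, none or still open, it means among the compounds named here.

In a functional assay on HeLa cells (Homo sapiens) for antiproliferative activity, read by MTT assay, with a stated time of 48 h (a higher number here means a weaker inhibitor, a lower number a stronger inhibitor), compound 1 `N#Cc1nc2c(-c3nc4ccccc4[nH]3)c(N)n(CCN3CCCC3)c2nc1C#N` gives > 50000 nM, which is a limit and not a number. Compound 2 `N#Cc1nc2c(-c3nc4ccccc4[nH]3)c(N)n(CCO)c2nc1C#N` gives > 50000 nM, again a limit. Compound 2 therefore stands at the limit of > 50000 nM in this assay, at which 2 of the 2 values shown sit. Compound 3 `CN1CCN(CCCn2c(N)c(-c3nc4ccccc4[nH]3)c3nc(C#N)c(C#N)nc32)CC1` differs from compound 2 by (4-methylpiperazin-1-yl)methyl in place of hydroxy on a saturated chain carbon, two bonds along the chain from an aromatic nitrogen. Going by the values given here, the only measured step at this place is a step that the two limits leave unreadable from compound 1 to compound 2, so it offers neither a size nor a direction, and no step beyond the scatter is expected in this assay. The estimate amounts to an expected at least 1.1-fold lower number from compound 2 to compound 3 (0.04 log units; that floor lies within the scatter). Compound 3 is expected at 45000 nM, with an estimated range of 12000 nM to 100000 nM.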

Compound 3, half-maximal inhibitory concentration: 15600 nM
The estimate for compound 3 lay 2.9-fold (0.46 log units) above the measured number; low and high end bracket the measured number.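

In this assay, compounds 1 and 2 left this position with only a limit and not a number: the limit of > 50000 nM in this assay, at which 2 of the 3 values shown sit. Compound 3, with its 3-(4-methylpiperazin-1-yl)propyl chain, gives the position its first readable number: against hydroxy the change is an at least 3.2-fold lower number from compound 2 to compound 3 (0.50 log units; beyond the scatter), and against pyrrolidin-1-yl it is an at least 3.2-fold lower number from compound 1 to compound 3 (0.50 log units; beyond the scatter). Both are floors, and the step between the two earlier compounds cannot be read.

Going by these compounds, the change alters the chain length and the end group together, so the part each plays stays open. A 2-(4-methylpiperazin-1-yl)ethyl or a 3-hydroxypropyl chain would separate them.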